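Swapping a Fused Two-Ring Arm for an Aminopyridine

The source may hold more compounds than are shown below. What is called first, only, known or untested is meant among the compounds shown, and "the series" means these compounds.

Two measured compounds share one core and differ from each other in more than one place. For the measured compounds named here, compound 1, `COc1cccc(Cn2cnc3sc(-c4ccnc(N)c4)cc3c2=O)c1`, is the first; in an assay on isolated protein for inhibition of Rho-associated protein kinase 2 (Homo sapiens), read by radiometric assay and 33P incorporation, with a stated time of 40 min, in the presence of a further agent that is not named here (a lower number here means a stronger inhibitor, a higher number a weaker inhibitor), compound 1 gives 1 nM. Compound 2, `O=c1c2cc(-c3ccnc4[nH]ccc34)sc2ncn1Cc1cccc(F)c1`, is the second; in this assay compound 2 gives 1 nM, level with compound 1 at the digits shown and within the usual scatter of it. Compound 3, `Nc1cc(-c2cc3c(=O)n(Cc4cccc(F)c4)cnc3s2)ccn1`, has not yet been measured. Going from compound 2 to compound 3 the change is a group of 7 heavy atoms (5 carbon, 2 nitrogen; one six-membered aromatic ring with 1 hetero atom) in place of a group of 9 heavy atoms (7 carbon, 2 nitrogen; one five-membered aromatic ring with 1 hetero atom, one six-membered aromatic ring with 1 hetero atom), on an aromatic carbon. Going by the values given here, no measured pair differs in only this one place, so the size of this step cannot be read off directly from a measured pair. Because compound 1 already carries the entering 2-aminopyridin-4-yl group and gives 1 nM, the step expected from compound 2 to compound 3 in this assay is a 1.5-fold higher number from compound 2 to compound 3 (0.18 log units; within the scatter), nothing beyond the scatter in either direction. Compound 3 is therefore estimated at 1.5 nM, with a range from 0.5 nM to 5 nM.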

Compound 3, half-maximal inhibitory concentration: 5 nM
Estimate against measurement, compound 3: 3.3-fold (0.52 log units) below; the measured number falls inside the stated range.
By their numbers in this assay, from the lowest: compounds 1 and 2 (each within the scatter of the next); then compound 3.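

Compound 3 is the link that lets single changes be read in this assay. With the fluoro held fixed, 2-aminopyridin-4-yl in place of the fused two-ring arm, on the aromatic carbon next to the ring sulfur, gives a 5.0-fold higher number from compound 2 to compound 3 (0.70 log units; beyond the scatter), a modest step. With the 2-aminopyridin-4-yl group held fixed, fluoro in place of methoxy gives a 5.0-fold higher number from compound 1 to compound 3 (0.70 log units; beyond the scatter), also modest. The level readings of compound 1 and compound 2 therefore did not mean that these two changes do nothing: that pair differs in two places, and each change, read alone against compound 3, has a size beyond the scatter.

As far as these compounds go, how the fused two-ring arm behaves alongside methoxy stays open, as does whether a chloro in place of the fluoro, or a pyridin-4-yl without its amine, would read closer to compound 1 or to compound 3. No measurement shown here accounts for either step.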